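The source may report more compounds than this note shows. Statements on the series, on what has been measured and on what is new or still open speak of the compounds shown alone.

Measured compounds in a functional assay on PPC-1 cells (Homo sapiens) for antiproliferative activity, read by sulforhodamine B assay; on this read-out lower numbers stand for stronger inhibition and higher numbers for weaker inhibition:
compound 1 `CCCCCCCCCCCCCCCCCCNC(=O)[C@H]1CSC(Cc2ccccc2)N1`: 4000 nM
compound 2 `CCCCCCCCCCCCCCCCCCNC(=O)[C@H]1CSC(c2c[nH]c3ccccc23)N1`: 1300 nM

Among the measured compounds shown here, compound 2 holds the lowest number of the two measured in this assay, with compound 1 the only neighbour; the step of a 3.1-fold lower number from compound 1 to compound 2 (0.49 log units; beyond the scatter) is beyond the scatter and came with 1H-indol-3-yl in place of benzyl on a saturated ring carbon.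

Compound 3 `CCCCCCCCCCCCCCCCCCNC(=O)[C@H]1CSC(c2cccnc2)N1` has not been measured. It differs from compound 2 in one place: pyridin-3-yl in place of 1H-indol-3-yl on a saturated ring carbon. For the measured compounds named here, the single measured step, a 3.1-fold lower number from compound 1 to compound 2 (0.49 log units; beyond the scatter), is the only one bearing on this change, and it concerns the same position of the shared core. That step shows that swapping the group on this ring carbon can move the number by a modest amount, but it does not show how pyridin-3-yl compares with either benzyl or 1H-indol-3-yl. The expectation is therefore a number no lower than that of compound 2 and a step of a 2.3-fold higher number from compound 2 to compound 3 (0.36 log units; beyond the scatter), near the scatter or slightly beyond it, toward compound 1. Compound 3 is estimated at 3000 nM, within 1000 nM to 9000 nM.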

Compound 3, half-maximal inhibitory concentration: 2900 nM
Estimate against measurement, compound 3: 1.0-fold (0.01 log units) above; measured number inside the range.
By their numbers in this assay, from the lowest: compound 2; then compounds 3 and 1 (each within the scatter of the next).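

In this assay, pyridin-3-yl in place of 1H-indol-3-yl gives a 2.2-fold higher number from compound 2 to compound 3 (0.35 log units; beyond the scatter), so the smaller aromatic group does not keep the advantage seen with 1H-indol-3-yl on this saturated ring carbon. Pyridin-3-yl in place of benzyl gives a 1.4-fold lower number from compound 1 to compound 3 (0.14 log units; within the scatter), so these two groups cannot be told apart on this read-out, and compound 2 now stands as the most potent of the three, with its steps to both others beyond the scatter. Nothing at hand explains why 1H-indol-3-yl differs from the other two groups.

The step from 1H-indol-3-yl to pyridin-3-yl changes the ring system, the hydrogen-bond donor count and the hydrogen-bond acceptor count together, so the compounds shown do not separate these changes; a 1-methyl-1H-indol-3-yl group or a plain phenyl group would bear on that question. Also open, on these data alone, is whether 1H-indol-3-yl keeps its advantage when the long chain of the shared core is replaced by a shorter chain or a carboxylic acid.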